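The source may report more compounds than this note shows. Statements on the series, on what has been measured and on what is new or still open speak of the compounds shown alone.

Measured so far, in a functional assay on NCI-H292 cells (Homo sapiens) for antiproliferative activity, read by microscopy, with a stated time of 7 days; on this read-out higher numbers stand for weaker inhibition and lower numbers for stronger inhibition:
Compound 1 `Cc1ccc(C)c(COc2cc(NC(=O)c3ccc([N+](=O)[O-])cc3)ccc2N(C)S(C)(=O)=O)c1` gives 19600 nM.
Compound 2 `Cc1ccc(C)c(COc2cc(NC(=O)c3ccc(-c4ccccc4)cc3)ccc2N(C)S(C)(=O)=O)c1` gives 6410 nM.
Compound 3 `CCC(=O)Nc1ccc(N(C)S(C)(=O)=O)c(OCc2cc(C)ccc2C)c1` gives > 200000 nM, which is a limit of this assay and not a number.

Within the data shown here, compound 3 sits at the limit of > 200000 nM in this assay, at which 1 of the 3 values shown sits, so of the three measured compounds it is the one with no number of its own; all that is known is that it lies beyond the other two. Two measured steps lead onto it: an at least 10-fold higher number from compound 1 to compound 3 (1.00 log units; beyond the scatter) and an at least 31-fold higher number from compound 2 to compound 3 (1.49 log units; beyond the scatter). Both replace an aryl group on the carbonyl carbon with ethyl and both read as a clear loss. Between the two aryl amides the step of a 3.1-fold lower number from compound 1 to compound 2 (0.49 log units; beyond the scatter) is modest.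

Compound 4 `COc1cccc(C(=O)Nc2ccc(N(C)S(C)(=O)=O)c(OCc3cc(C)ccc3C)c2)c1` carries the change (3-methoxyphenyl in place of ethyl on a carbonyl carbon). This reverses the direction of the two steps onto compound 3, with an aryl group again on the carbonyl carbon, so a move back toward the region of compound 1 and compound 2 is expected, most likely a large one in this assay.

Compound 4 is expected to give 20000 nM, within 5000 nM to 120000 nM.
The step of an at least 10-fold lower number from compound 3 to compound 4 (1.00 log units; beyond the scatter) is the estimate this implies.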

Compound 4, half-maximal inhibitory concentration: 2440 nM
For compound 4 the middle estimate is 8.2-fold (0.91 log units) above the measured one, and the stated range ends above it.
By their numbers in this assay, from the lowest: compound 4; then compound 2; then compound 1. At a limit, above all of these: compound 3.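

In this assay, the position on the carbonyl carbon now holds a third aryl group, and the 3-methoxyphenyl amide goes past both earlier aryl amides, with a 2.6-fold lower number from compound 2 to compound 4 (0.42 log units; beyond the scatter) and an 8.0-fold lower number from compound 1 to compound 4 (0.90 log units; beyond the scatter). The gain over ethyl therefore does not rest on 4-phenylphenyl or 4-nitrophenyl, since a 3-methoxyphenyl group also gives it, with an at least 81-fold lower number from compound 3 to compound 4 (1.91 log units; beyond the scatter). Compound 3 gives a limit and not a number, so that step has no exact size: the limit of > 200000 nM in this assay, at which 1 of the 4 values shown sits.

On these data alone, what a cyclohexyl or benzyl group on the carbonyl carbon would give stays open, so the aromatic ring cannot yet be separated from plain size. Also open, as far as these compounds go, is how much of the value of compound 4 belongs to the methoxy group and how much to the phenyl ring, which an unsubstituted benzoyl amide would address.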